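Chain extension on a simpler core: from compound 3 to compound 4

A few compounds are considered here, and "the series" means these few. Any claim that something is new, unique, unknown or untested is made for them only; others in the source may bear on it.

Measured in an assay on isolated protein for inhibition of phosphodiesterase 1 (Bos taurus), read by cAMP accumulation; a higher number here means a weaker inhibitor, a lower number a stronger inhibitor:
Compound 1 `CNc1ccc(C2c3ccccc3N=C(NCCCNCCCCN)C2(C)C)cc1` gives 64000 nM.
Compound 2 `CNc1ccc(C2c3ccccc3N=C(NCCCNCCCCNCCCN)C2(C)C)cc1` gives 23000 nM.
Compound 3 `NCCCCNCCCNC1=Nc2ccccc2CC1` gives > 500000 nM.

Compound 3 stands apart from the other two: its result is not a number but a limit, namely (the limit of > 500000 nM in this assay, at which 1 of the 3 values shown sits). So only the floor of its weakness is known, not how far beyond it the true value lies.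

Compound 4 `NCCCNCCCCNCCCNC1=Nc2ccccc2CC1` is built from compound 3 by one change: 3-aminopropyl in place of hydrogen on an amine nitrogen. The same change has been measured once on a different core, where it gave a 2.8-fold lower number from compound 1 to compound 2 (0.44 log units; beyond the scatter). If that step carries over, compound 4 should come out somewhat stronger than compound 3 in this assay, but because compound 3 sits at the limit of > 500000 nM in this assay, at which 1 of the 3 values shown sits, a modest gain may still leave compound 4 at or near that limit.

The estimate for compound 4 is therefore 350000 nM, with a range from 120000 nM to 1000000 nM, which means an expected step of an at least 1.4-fold lower number from compound 3 to compound 4 (0.15 log units; that floor lies within the scatter).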

Compound 4, half-maximal inhibitory concentration: > 500000 nM
Compound 4 gave a limit, no number; the forecaster's own chance of this, stated with the estimate: 50%; at least 1.4-fold (0.15 log units) between middle value and limit.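

Compound 3 and compound 4 both return only a limit in this assay, so no step can be read between them: the limit of > 500000 nM in this assay, at which 2 of the 4 values shown sit.

From the compounds shown here alone, whether 3-aminopropyl in place of hydrogen on this simpler core shifts the true value at all remains open.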